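The source may hold more compounds than are shown below. What is called first, only, known or untested is meant among the compounds shown, and "the series" means these compounds.

Compound 1 `COCc1ncc2cnnc(SC)n12` and compound 2 `COCc1ncc2cnnc(S)n12` share one core and differ by hydrogen in place of methyl on a sulfur. In a functional assay for inhibition, with Homo sapiens as the target (a higher number here means a weaker inhibitor, a lower number a stronger inhibitor), compound 1 gives > 48000 nM, which is a limit of the assay rather than a number. In this assay compound 2 gives > 48000 nM, likewise a limit. The step from the first to the second is therefore a step that the two limits leave unreadable from compound 1 to compound 2. Compound 3 `CCCc1nnc(SC)n2c(CCC)nc(C)c12` carries a different core; how the two cores differ is not broken down here. In this assay compound 3 gives > 48000 nM, again a limit. Taken together, (the limit of > 48000 nM in this assay, at which 3 of the 3 values shown sit). Compound 4 `CCCc1nnc(S)n2c(CCC)nc(C)c12` is made from compound 3 by hydrogen in place of methyl on a sulfur, the same change as before. For compound 4 the estimate is 100000 nM, a step that the limit leaves unreadable from compound 3 to compound 4, resting on the fact that compound 3 sits at > 48000 nM and that the earlier pair stayed at the limit.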

Compound 4, half-maximal inhibitory concentration: > 48000 nM
Compound 4: only a limit was reported; the forecaster's own chance of this, stated with the estimate: 85%; the middle value does not contradict the limit.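

Compound 3 and compound 4 both stand only at a limit of this assay, so no step can be read between them. Whether hydrogen in place of methyl on a sulfur alters inhibition stays open, as does what any of these compounds would give below that limit: the limit of > 48000 nM in this assay, at which 4 of the 4 values shown sit.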